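The source may report more compounds than this note shows. Statements on the series, on what has been measured and on what is new or still open speak of the compounds shown alone.

Of the compounds shown here, three that share one core have been measured in an assay on thoracic aorta for inhibition of Voltage-gated L-type calcium channel (Rattus norvegicus); on this read-out lower numbers stand for stronger inhibition and higher numbers for weaker inhibition. Compound 1 `COC(OC)C1=C(C(=O)OC/C=C/c2ccccc2)C(c2cccc(Cl)c2)C(C(=O)O)=C(C)N1` gives 8100 nM. Compound 2 `CCC1=C(C(=O)OC/C=C/c2ccccc2)C(c2cccc(Cl)c2)C(C(=O)O)=C(C)N1` gives 7 nM. Compound 3 `COC(OC)C1=C(C(=O)OC/C=C/c2ccccc2Cl)C(c2cccc(Cl)c2)C(C(=O)O)=C(C)N1` gives 700 nM, the second highest of the three numbers: compound 1 stands nearest to it, compound 2 furthest. Among the single changes, there was a 1200-fold lower number from compound 1 to compound 2 (3.06 log units; beyond the scatter), with ethyl in place of dimethoxymethyl on a double-bonded ring carbon; that change sits far from the ring discussed next.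

Compound 4 `COC(OC)C1=C(C(=O)OC/C=C/c2cccc(Cl)c2)C(c2cccc(Cl)c2)C(C(=O)O)=C(C)N1` has not yet been measured. It differs from compound 3 by 3-chlorophenyl in place of 2-chlorophenyl on a double-bonded chain carbon bound to a double-bonded chain carbon. Among the compounds with values here, only one measured step touches this ring: there was a 12-fold lower number from compound 1 to compound 3 (1.06 log units; beyond the scatter), which put chloro in place of hydrogen on an aromatic carbon. Within the data shown here, that step shows that a chlorine on this ring makes a large difference, but it does not say whether a 3-chlorophenyl works as well as a 2-chlorophenyl, since no measured pair moves a chlorine from one aromatic carbon to another. The step from compound 3 to compound 4 is therefore expected to be small, a 1.2-fold lower number from compound 3 to compound 4 (0.07 log units; within the scatter), and it could run in either direction. Compound 4 is expected to give 600 nM, within a range from 120 nM to 3000 nM.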

Compound 4, half-maximal inhibitory concentration: 1000 nM
Compound 4: middle estimate off by 1.7-fold (0.22 log units), on the low side; low and high end bracket the measured number.
By their numbers in this assay, from the lowest: compound 2; then compounds 3 and 4 (each within the scatter of the next); then compound 1.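

Moving the chlorine, from 2-chlorophenyl to 3-chlorophenyl on the double-bonded chain carbon, gives a 1.4-fold higher number from compound 3 to compound 4 (0.15 log units; within the scatter) in this assay, so this read-out does not separate these two placements of the chlorine. The gain from adding a chlorine to the unsubstituted phenyl of compound 1 is therefore not tied to one placement: alongside a 12-fold lower number from compound 1 to compound 3 (1.06 log units; beyond the scatter), there is now an 8.1-fold lower number from compound 1 to compound 4 (0.91 log units; beyond the scatter), and both steps lie beyond the scatter. No measurement is available that explains why a chlorine on this ring matters or why these two placements read alike.

On these data alone, it remains open whether the chlorine itself is needed on this ring, or whether another group, such as fluoro, methyl or methoxy, would serve in its place. As far as these compounds go, it also remains open whether either chlorophenyl would still make a difference with ethyl in place of dimethoxymethyl, where compound 2 already gives 7 nM.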